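Aryl swap on the anilino nitrogen: compound 3 to compound 4

A few compounds are considered here, and "the series" means these few. Any claim that something is new, unique, unknown or untested is made for them only; others in the source may bear on it.

Three compounds of the series have numbers in a functional assay on HCC827 cells (Homo sapiens) for inhibition, read by MTT assay, with a stated time of 48 h, tested at 10 uM; a higher number here means more inhibition at the concentration tested (going by the name of the read-out), a lower number less inhibition. Compound 1 `COc1cc(NC(=O)Nc2cc(Nc3ccc(C)c(F)c3)ncn2)cc(OC)c1` gives 72%. Compound 2 `COc1cc(NC(=O)Nc2cc(Nc3cc(F)ccc3OC)ncn2)cc(OC)c1` gives 59%. Compound 3 `COc1cc(NC(=O)Nc2cc(Nc3cc(Br)ccc3OC)ncn2)cc(OC)c1` gives 76.3%, the largest of the three numbers; one of its steps, a number 4.3 percentage points higher from compound 1 to compound 3 (within the scatter), stays within the scatter, while the other, a number 17.3 percentage points higher from compound 2 to compound 3 (beyond the scatter), lies beyond it. Among the compounds with values here, the third step, a number 13 percentage points lower from compound 1 to compound 2 (beyond the scatter), shows the only other change beyond the scatter.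

Compound 4 `COc1cc(NC(=O)Nc2cc(Nc3ccc(OC)c(C)c3)ncn2)cc(OC)c1` is not yet measured. Its change from compound 3 is 4-methoxy-3-methylphenyl in place of 5-bromo-2-methoxyphenyl on a nitrogen on an aromatic ring. Within the data shown here, the steps that bear on it are those that replace the whole aryl group on the same nitrogen: a number 4.3 percentage points higher from compound 1 to compound 3 (within the scatter) stayed within the scatter, and a number 13 percentage points lower from compound 1 to compound 2 (beyond the scatter) was a modest fall. The aryl group entering in compound 4 carries a methyl, as does the group in compound 1, and a methoxy, as do the groups in compounds 2 and 3. Against that background no step beyond the scatter is expected for compound 4, with a slight lean downward.

Compound 4 is therefore expected at 66%, between 48% and 80%, an expected step of a number 10.3 percentage points lower from compound 3 to compound 4 (beyond the scatter).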

Compound 4, a percentage reported as inhibition, at one concentration (the size of the read-out at that concentration, not a potency): 48.3%
For compound 4 the middle estimate is 17.7 percentage points above the measured one; the measured number falls inside the stated range.
By their numbers in this assay, from the lowest: compound 4; then compound 2; then compounds 1 and 3 (each within the scatter of the next).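

In this assay, replacing the aryl group on this nitrogen now gives falls beyond the scatter against all three earlier compounds: a number 28 percentage points lower from compound 3 to compound 4 (beyond the scatter), a number 23.7 percentage points lower from compound 1 to compound 4 (beyond the scatter), and a number 10.7 percentage points lower from compound 2 to compound 4 (beyond the scatter), which makes compound 4 the lowest of the four. Before this result, compound 2 marked the low end, so the series now shows that the whole-aryl swap at this position can cost more than the earlier steps indicated, and that carrying a methyl, as in compound 1, together with a methoxy, as in compounds 2 and 3, does not by itself hold the number at the level of any of those compounds. No measurement is available that bears on the reason for this fall.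

On these data alone, how much of the fall belongs to the methyl and how much to the placement of the methoxy in 4-methoxy-3-methylphenyl remains open, as does the loss of the bromo from the group in compound 3. Also open, as far as these compounds go, is how the number would respond to an amine or a carboxylic acid on this aryl ring.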